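A Single Stereocentre Flipped in a Weakly Cytotoxic Series

This account rests on a few compounds, and the source may have more. Where it says the series, first, only, none or still open, it means among the compounds named here.

Measured so far in a functional assay on HL-60 cells (Homo sapiens) for cytotoxicity, read by WST assay, with a stated time of 48 h; a lower number here means a stronger inhibitor, a higher number a weaker inhibitor:
compound 1 `COc1cc(C(c2ccc(O)c(OC)c2)[C@@H](C)[C@H](C)CO)ccc1O` gives > 100000 nM.
compound 2 `COc1ccc(C(c2ccc(OC)c(OC)c2)[C@H](C)[C@@H](C)CO)cc1OC` gives 47000 nM.
compound 3 `COC[C@H](C)[C@@H](C)C(c1ccc(O)c(OC)c1)c1ccc(O)c(OC)c1` gives 68000 nM.

Compound 1 has the value > 100000 nM, which is a limit of the assay, not a number. Among the two actual numbers, compound 3 holds the higher one, while compound 2 lies within the usual scatter of it, so no order between those two can be claimed. Among the compounds with values here, the one measured step, an at least 1.4-fold lower number from compound 1 to compound 3 (0.16 log units; that floor lies within the scatter), starts from a limit of > 100000 nM in this assay, at which 1 of the 3 values shown sits, and gives a floor that itself lies within the scatter, so it says little about size.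

Compound 4 `COC[C@H](C)[C@H](C)C(c1ccc(O)c(OC)c1)c1ccc(O)c(OC)c1` differs from compound 3 by the two compounds have the same atoms and bonds and differ only in configuration as drawn: 1 of 2 stereo elements differ; a stereocentre at a saturated chain carbon is drawn S in compound 3 and R in compound 4. Within the data shown here, no measured step concerns a change of configuration alone, so there is nothing to carry over. The expectation for compound 4 is therefore a step of about no change at the digits printed from compound 3 to compound 4 (within the scatter), that is, none beyond the scatter. Compound 4 is estimated at 68000 nM, with a range from 25000 nM to 150000 nM.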

Compound 4, half-maximal inhibitory concentration: 82000 nM
The estimate for compound 4 lay 1.2-fold (0.08 log units) below the measured number; the measured number falls inside the stated range.
By their numbers in this assay, from the lowest: compounds 2, 3 and 4 (each within the scatter of the next). At a limit, above all of these: compound 1.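

Inverting this one stereocentre on the saturated chain gives the first view of configuration alone in the series, and in this assay the result is small (a 1.2-fold higher number from compound 3 to compound 4 (0.08 log units; within the scatter)). The comparison isolates that single change: the fact that compounds 3 and 4 differ only in the configuration as drawn. The other new step (an at least 1.2-fold lower number from compound 1 to compound 4 (0.08 log units; that floor lies within the scatter)) puts the methoxymethyl group in place of the hydroxymethyl group in this configuration, but it starts from a limit and not a number, so it gives only a floor and says little about size: the limit of > 100000 nM in this assay, at which 1 of the 4 values shown sits.

Going by these compounds, whether the other stereocentre, or this one in compounds carrying the hydroxymethyl group, behaves in the same way remains open. So does whether an amine, a carboxylic acid or a longer chain in place of the methoxymethyl group would give a clearly lower number on the same core.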